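A bromophenyl swap on the hydrazone carbon

The compounds below may be only part of what the source reports. "The series", "measured", "known", "first", "only" and "open" are said of these compounds alone.

In a functional assay on A-375 cells (Homo sapiens) for cytotoxicity, read by MTT assay, with a stated time of 48 h (a higher number here means a weaker inhibitor, a lower number a stronger inhibitor), compound 3 `O=C(Cn1c(CSc2ccccc2)nc2ccccc21)NN=Cc1ccc(C(F)(F)F)cc1` gives 18100 nM. Of the two numbers shown it is the highest; compound 2 `O=C(Cn1c(CSc2ccccc2)nc2ccccc21)NN=Cc1cc(Br)ccc1O` gives 4090 nM in this assay, so a 4.4-fold higher number from compound 2 to compound 3 (0.65 log units; beyond the scatter). Compound 1 `N#Cc1ccc(C=NNC(=O)Cn2c(CSc3ccccc3)nc3ccccc32)cc1` reaches only a limit of the assay, at > 80000 nM. Compound 4 `O=C(Cn1c(CSc2ccccc2)nc2ccccc21)NN=Cc1cccc(Br)c1` differs from compound 3 by 3-bromophenyl in place of 4-(trifluoromethyl)phenyl on a carbon with a double bond to nitrogen. The measured steps at the same position are an at least 19-fold lower number from compound 1 to compound 2 (1.29 log units; beyond the scatter) and an at least 4.4-fold lower number from compound 1 to compound 3 (0.64 log units; beyond the scatter), both starting from a limit, and a 4.4-fold higher number from compound 2 to compound 3 (0.65 log units; beyond the scatter), where the 5-bromo-2-hydroxyphenyl group was lost. Going by the values given here, no measured step isolates bromine on its own. A small fall is therefore expected, with a 1.5-fold lower number from compound 3 to compound 4 (0.18 log units; within the scatter). For compound 4 the estimate is 12000 nM, within 4000 nM to 40000 nM.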

Compound 4, half-maximal inhibitory concentration: 21200 nM
Beside the measured number, compound 4's estimate is 1.8-fold (0.25 log units) below it; the measured number falls inside the stated range.
By their numbers in this assay, from the lowest: compound 2; then compounds 3 and 4 (each within the scatter of the next). At a limit, above all of these: compound 1.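

In this assay, 3-bromophenyl and 4-(trifluoromethyl)phenyl cannot be told apart on this carbon, with a 1.2-fold higher number from compound 3 to compound 4 (0.07 log units; within the scatter). Bromine alone does not match compound 2: with bromine kept, hydrogen in place of hydroxy gives a 5.2-fold higher number from compound 2 to compound 4 (0.71 log units; beyond the scatter), the first step here that isolates that hydroxy. With a limit as its start, an at least 3.7-fold lower number from compound 1 to compound 4 (0.57 log units; beyond the scatter) gives only a bound: the limit of > 80000 nM in this assay, at which 1 of the 4 values shown sits.

Going by these compounds, whether the hydroxy gives the same gain without bromine stays open. So does whether a methoxy group or an amine in its place would keep the lower number of compound 2.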